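A few compounds are considered here, and "the series" means these few. Any claim that something is new, unique, unknown or untested is made for them only; others in the source may bear on it.

Measured so far in a functional assay on FM3A cells (Mus musculus) for inhibition; on this read-out lower numbers stand for stronger inhibition and higher numbers for weaker inhibition:
- compound 1 `O=C1O/C(=C\Cn2cc(C(F)(F)F)c(=O)[nH]c2=O)C(OCc2ccccc2)=C1OCc1ccccc1`: 3600 nM
- compound 2 `O=C1O/C(=C\Cn2cc(I)c(=O)[nH]c2=O)C(OCc2ccccc2)=C1OCc1ccccc1`: 22600 nM

Compound 2, at 22600 nM, holds the higher of the two numbers, so it is the weaker inhibitor of this pair. The next compound is compound 3 `O=C1O/C(=C\Cn2ccc(=O)[nH]c2=O)C(OCc2ccccc2)=C1OCc1ccccc1`, which has not yet been measured. The change from compound 2 is hydrogen in place of iodo on an aromatic carbon.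

Within the data shown here, only one measured step bears on this: a 6.3-fold higher number from compound 1 to compound 2 (0.80 log units; beyond the scatter), with iodo in place of trifluoromethyl on that same carbon. It is a modest step, but beyond the scatter, and it shows that the group at this carbon can move the number in this assay. Among the measured compounds shown here, no measured compound carries hydrogen there, so the direction of the new step is not established. For the measured compounds named here, the single step from compound 1 to compound 2 gives a size to work with, not a trend. Going by the values given here, no step clearly beyond the scatter is expected, with only a slight lean towards a lower number. The estimated step is a 1.4-fold lower number from compound 2 to compound 3 (0.15 log units; within the scatter). For compound 3 the expected value is 16000 nM, with an estimated range of 4500 nM to 55000 nM.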

Compound 3, half-maximal inhibitory concentration: 17700 nM
The estimate for compound 3 lay 1.1-fold (0.04 log units) below the measured number, within the range that was stated.
By their numbers in this assay, from the lowest: compound 1; then compounds 3 and 2 (each within the scatter of the next).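

In this assay, hydrogen in place of iodo on this aromatic carbon gives a 1.3-fold lower number from compound 2 to compound 3 (0.11 log units; within the scatter) and leaves iodo and hydrogen indistinguishable at this position. Trifluoromethyl is now the only one of the three groups that stands apart, with a 4.9-fold higher number from compound 1 to compound 3 (0.69 log units; beyond the scatter) alongside a 6.3-fold higher number from compound 1 to compound 2 (0.80 log units; beyond the scatter) in the earlier comparison, so the earlier step reads as a difference tied to trifluoromethyl in compound 1 and not as a loss tied to iodo in compound 2. No measured evidence bears on the reason for this separation.

The three compounds do not show whether trifluoromethyl is unusual at this carbon or whether other groups, such as a nitrile, a methyl, an amine or a carboxylic acid, would match compound 1 or fall with compound 2 and compound 3. On these data alone, it also remains open whether the separation of compound 1 from the other two would persist if the benzyl ethers on the shared core were replaced, for example by shorter alkyl ethers or free hydroxyl groups.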